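Swapping Halogens on an Aryl Amine: Expected Clearance

The source may report more compounds than this note shows. Statements on the series, on what has been measured and on what is new or still open speak of the compounds shown alone.

Of the compounds shown here, three built on one shared core have been measured in an ADME assay on cells (Hepatocyte, Homo sapiens) for metabolic stability, read by LC-MS, with a stated time of 60 min, tested at 1 uM; on this read-out higher numbers stand for fast clearance and lower numbers for slow clearance. Compound 1 `COc1cc(N(CC2CC2)c2ccc(Cl)c(Cl)c2)cnc1C(=O)[C@H]1C[C@@H]1C(=O)O` gives 4.3 uL/min. Compound 3 `COc1cc(N(CC(C)C)c2cccc(C(F)(F)F)c2)cnc1C(=O)[C@H]1C[C@@H]1C(=O)O` gives 2.9 uL/min, and compound 2 `CCCN(c1cnc(C(=O)[C@H]2C[C@@H]2C(=O)O)c(OC)c1)c1ccc(F)c2ccccc12` gives 7.6 uL/min. Compound 1 holds the second highest of these three numbers, but its gaps to compound 3 and to compound 2 both lie within the usual scatter, so the three cannot be told apart with confidence. Compound 4 `COc1cc(N(CC2CC2)c2cc(Cl)ccc2F)cnc1C(=O)[C@H]1C[C@@H]1C(=O)O` has not yet been measured. It differs from compound 1 in one place: 5-chloro-2-fluorophenyl in place of 3,4-dichlorophenyl on a nitrogen on an aromatic ring. Within the data shown here, no measured pair shows the effect of such a change, so the step of a 1.0-fold higher number from compound 1 to compound 4 (0.02 log units; within the scatter) is expected to be small, in no set direction, and within the scatter. Compound 4 is therefore expected to give about 4.5 uL/min in this assay, between 2 uL/min and 10 uL/min.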

Compound 4, intrinsic clearance in a liver preparation (reported as CLH), per the amount of preparation that the assay uses: 1.3 uL/min
Estimate against measurement, compound 4: 3.5-fold (0.54 log units) above, outside the stated range (below it).
By their numbers in this assay, from the lowest: compound 4; then compounds 3, 1 and 2 (each within the scatter of the next, the first and the last beyond it).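

In this assay, among these compounds, the aryl group on this nitrogen turns out to matter: 5-chloro-2-fluorophenyl in place of 3,4-dichlorophenyl gives a 3.3-fold lower number from compound 1 to compound 4 (0.52 log units; beyond the scatter), the first step here that differs in one place. Both groups keep the same heavy-atom count, so a swap of this size can still shift the number. Nothing at hand explains the step. On these data alone, whether the fluorine or the different chlorine pattern carries it stays open. So does the outcome with a nitrile or a methyl group on this aryl ring.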